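A few compounds are considered here, and "the series" means these few. Any claim that something is new, unique, unknown or untested is made for them only; others in the source may bear on it.

Values in a functional assay on HCT-116 cells (Homo sapiens) for inhibition, read by MTT assay, with a stated time of 48 h (on this read-out lower numbers stand for stronger inhibition and higher numbers for weaker inhibition), for the compounds measured so far

- compound 1 `CCCCC(=O)N(Cc1ccc(OC)c(O)c1)c1cc(OC)c(OC)c(OC)c1` gives 170 nM
- compound 2 `COc1ccc(CN(C(=O)C=C(C)C)c2cc(OC)c(OC)c(OC)c2)cc1O` gives 290 nM
- compound 3 `CC/C=C/C(=O)N(Cc1ccc(OC)c(O)c1)c1cc(OC)c(OC)c(OC)c1` gives 63 nM

Compound 3 stands lowest of the three. Both a 2.7-fold lower number from compound 1 to compound 3 (0.43 log units; beyond the scatter) and a 4.6-fold lower number from compound 2 to compound 3 (0.66 log units; beyond the scatter) lie beyond the scatter, while a 1.7-fold higher number from compound 1 to compound 2 (0.23 log units; within the scatter) stays within it.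

Compound 4 `COc1ccc(CN(C(=O)CCl)c2cc(OC)c(OC)c(OC)c2)cc1O` has not yet been measured and keeps the shared core. The change chloromethyl in place of but-1-en-1-yl on a carbonyl carbon puts chloromethyl in place of but-1-en-1-yl on a carbonyl carbon. For the measured compounds named here, all three measured steps are changes on that same carbonyl carbon, so they are the only guide here, but none of them brings in chloromethyl. They show that replacing the group on this carbon has so far moved the number only modestly. Since compound 3 at 63 nM is the lowest value seen, a replacement of its group is expected to give a higher number rather than a lower one, probably of modest size and with a wide margin. The step expected is a 4.0-fold higher number from compound 3 to compound 4 (0.60 log units; beyond the scatter) in this assay on this estimate. The estimate for compound 4 is 250 nM with an expected range of 60 nM to 1100 nM on this read-out.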

Compound 4, half-maximal inhibitory concentration: 250 nM
Beside the measured number, compound 4's estimate shows no gap at the digits printed, within the range that was stated.
By their numbers in this assay, from the lowest: compound 3; then compounds 1, 4 and 2 (each within the scatter of the next).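

In this assay, putting chloromethyl on the carbonyl carbon in place of but-1-en-1-yl gives a 4.0-fold higher number from compound 3 to compound 4 (0.60 log units; beyond the scatter) and so extends the lead of compound 3 to a third kind of group, one that carries chlorine and has no double bond outside aromatic rings. Set against the other two groups, chloromethyl shows a 1.2-fold lower number from compound 2 to compound 4 (0.06 log units; within the scatter) and a 1.5-fold higher number from compound 1 to compound 4 (0.17 log units; within the scatter) and so cannot be told apart from 2-methylprop-1-en-1-yl or butyl in this assay, which leaves but-1-en-1-yl as the only group of the four that stands beyond the scatter from all the others. Nothing measured here accounts for why but-1-en-1-yl stands apart from the other three groups.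

The compounds shown leave open how a longer alkenyl chain such as hex-1-en-1-yl, or bromomethyl or an aminomethyl group, would read on this same carbonyl carbon. They also leave open whether the lead of but-1-en-1-yl would hold in a cell line other than the one used here, or with the hydroxy group of the shared core replaced by a methoxy group.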